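This account rests on a few compounds, and the source may have more. Where it says the series, first, only, none or still open, it means among the compounds named here.

Measured in an ADME assay on the whole organism for pharmacokinetics, with Rattus norvegicus as the target, at a dose of 1 mg/kg by the intravenous route; a higher number here means faster removal of the compound, a lower number slower removal:
- compound 1 `Cc1ccc(C(=O)O)c(CC[C@@H]2CCC[C@@H]2NC(=O)C2CCN(c3ccc(C(F)(F)F)cc3)CC2)c1`: 9 mL/min/kg
- compound 2 `Cc1cccc2ccc(N3CCC(C(=O)N[C@H]4CCC[C@H]4CCc4ccccc4C(=O)O)CC3)nc12`: 31 mL/min/kg

Compound 1, at 9 mL/min/kg, holds the lower of the two numbers in this assay. Compound 2 stands higher at 31 mL/min/kg, and the gap between them lies beyond the usual scatter. These two compounds do not differ in one place only, so their gap says nothing about any single structural change.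

Compound 3 `O=C(O)c1cccnc1CC[C@@H]1CCC[C@@H]1NC(=O)C1CCN(c2ccc(C(F)(F)F)cc2)CC1` has not yet been measured. It keeps the core of compound 1 but carries 3-carboxypyridin-2-yl in place of 2-carboxy-5-methylphenyl on a saturated chain carbon, two bonds along the chain from a saturated ring carbon. For the measured compounds named here, no measured pair shows this change on its own, so the expectation has no direct precedent and stays cautious. Only a small move towards slower removal is expected, one that would not clearly exceed the scatter: a 1.3-fold lower number from compound 1 to compound 3 (0.11 log units; within the scatter). In this assay compound 3 is estimated at 7 mL/min/kg, with an expected range from 3 mL/min/kg to 18 mL/min/kg.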

Compound 3, clearance: 38 mL/min/kg
Beside the measured number, compound 3's estimate is 5.4-fold (0.73 log units) below it; the whole stated range lies below it.
By their numbers in this assay, from the lowest: compound 1; then compounds 2 and 3 (each within the scatter of the next).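

In this assay, placing 3-carboxypyridin-2-yl in place of 2-carboxy-5-methylphenyl on a saturated chain carbon, two bonds along the chain from a saturated ring carbon, gives a 4.2-fold higher number from compound 1 to compound 3 (0.63 log units; beyond the scatter) on the otherwise unchanged core of compound 1. For the compounds shown here, this is the first comparison in the set that isolates one place in the structure, and its size, beyond the usual scatter, shows that the number in this assay is sensitive to the aryl group at the end of this chain. The swap removes a ring of carbon only and brings in a ring with 1 hetero atom, while the group keeps its carboxylic acid and its link to the chain, but no measurement on hand gives a reason for the rise.

Going by these compounds alone, the single step cannot say whether the ring nitrogen or the loss of the methyl group carries the effect, as both arrive together, and a 3-carboxypyridin-2-yl ring bearing a methyl group would be the direct test. On these data alone, how a tetrazole in place of the carboxylic acid, or a longer chain, would behave at this place also stays open.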